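A few compounds are considered here, and "the series" means these few. Any claim that something is new, unique, unknown or untested is made for them only; others in the source may bear on it.

Measured so far, in a functional assay on HCT-116 cells (Homo sapiens) for inhibition, read by CCK-8 assay, with a stated time of 48 h; on this read-out lower numbers stand for stronger inhibition and higher numbers for weaker inhibition:

compound 1 (`COc1cc(-c2ccnc3cc(-c4ccccc4)nn23)cc(OC)c1OC`): 3880 nM
compound 2 (`COc1cc(-c2ccnc3cc(-c4ccc(C(F)(F)F)cc4)nn23)cc(OC)c1OC`): 1860 nM

Going by the values given here, compound 2 holds the lower of the two numbers, and the only comparison available is compound 1, which sits higher. Next in the series is compound 3 (`COc1cc(-c2ccnc3cc(-c4ccc(N(C)C)cc4)nn23)cc(OC)c1OC`), with dimethylamino in place of trifluoromethyl on an aromatic carbon, para to a large group (dimethylamino in place of trifluoromethyl on an aromatic carbon).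

Among the compounds with values here, one measured step bears on this change: the exchange of hydrogen for trifluoromethyl (a 2.1-fold lower number from compound 1 to compound 2 (0.32 log units; beyond the scatter)), which is modest. Within the data shown here, compound 3 gives up that trifluoromethyl, but no measured compound carries dimethylamino, so the data offer no direct guide to the entering group. The working expectation in this assay is therefore a small move toward a higher number, probably not clearly beyond the scatter, with compound 1 (3880 nM) as the nearest reference on the high side. The expected step is small (a 1.3-fold higher number from compound 2 to compound 3 (0.11 log units; within the scatter)) and uncertain in size. For compound 3 the estimate is 2400 nM, with an expected range from 700 nM to 7000 nM and the wide margin reflecting how little the series yet shows.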

Compound 3, half-maximal inhibitory concentration: 2050 nM
Beside the measured number, compound 3's estimate is 1.2-fold (0.07 log units) above it; measured number inside the range.
By their numbers in this assay, from the lowest: compounds 2, 3 and 1 (each within the scatter of the next, the first and the last beyond it).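

In this assay, replacing trifluoromethyl with dimethylamino on the aromatic carbon para to a large group gives a 1.1-fold higher number from compound 2 to compound 3 (0.04 log units; within the scatter), so this pair does not separate the two groups, even though they differ in their counted hydrogen-bond acceptors. Measured against the hydrogen of compound 1, dimethylamino gives a 1.9-fold lower number from compound 1 to compound 3 (0.28 log units; within the scatter), while trifluoromethyl gives a 2.1-fold lower number from compound 1 to compound 2 (0.32 log units; beyond the scatter); only the trifluoromethyl step clears the scatter, and compound 3 cannot be separated from either neighbouring compound on its own steps. No measurement available here explains this pattern or links it to any feature of the two groups.

As far as these compounds go, it remains open whether a carboxylic acid, a primary amine, a methoxy group or a longer alkyl chain at this same place would separate clearly from trifluoromethyl and dimethylamino, or whether all such replacements would stay within the narrow span seen so far. From the compounds shown here alone, it is also open whether changes elsewhere on the shared core would move the number further than any change at this position has.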